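A few compounds are considered here, and "the series" means these few. Any claim that something is new, unique, unknown or untested is made for them only; others in the source may bear on it.

In an assay on isolated protein for displacement of a labelled ligand from metabotropic glutamate receptor 5 (Homo sapiens), with a stated time of 60 min, tested at 1 uM (on this read-out lower numbers stand for less inhibition and higher numbers for more inhibition at the one concentration tested (going by the name of the read-out)), compound 1 `Cc1ccc2ncc(S(=O)(=O)c3ccc(F)cc3)c(N3CCC(C)CC3)c2c1` gives 90%, compound 3 `Cc1ccc(S(=O)(=O)c2cnc3ccc(C)cc3c2N2CCC(C)CC2)cc1` gives 82%, and compound 2 `Cc1ccc2ncc(S(=O)(=O)c3cccc(C#N)c3)c(N3CCC(C)CC3)c2c1` gives 52%, the lowest of the three: a number 30 percentage points higher from compound 2 to compound 3 (beyond the scatter), and a number 38 percentage points lower from compound 1 to compound 2 (beyond the scatter). Compound 4 `CC1CCN(c2c(S(=O)(=O)c3cccc(C#N)c3)cnc3ccc(Cl)cc23)CC1` differs from compound 2 by chloro in place of methyl on an aromatic carbon. Among the compounds with values here, no measured step exchanges methyl for chloro, so the bearing is indirect. Within the data shown here, the two large steps both changed the group on the sulfonyl sulfur, whereas the only step at an aromatic carbon, a number 8 percentage points lower from compound 1 to compound 3 (within the scatter), stayed within the scatter. The present change is therefore expected to produce no step beyond the scatter: no change at the digits printed from compound 2 to compound 4 (within the scatter). Compound 4 is estimated at 52%, with a range from 35% to 70%.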

Compound 4, a percentage reported as inhibition, at one concentration (the size of the read-out at that concentration, not a potency): 90%
Estimate against measurement, compound 4: 38 percentage points below, and the stated range ends below it.
By their numbers in this assay, from the lowest: compound 2; then compounds 3, 1 and 4 (each within the scatter of the next).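

In this assay, chloro in place of methyl on this aromatic carbon gives a number 38 percentage points higher from compound 2 to compound 4 (beyond the scatter) with 3-cyanophenyl kept on the sulfonyl sulfur. The earlier compounds shown here all carried methyl here, so only changes at the sulfonyl group had been seen; this step shows that a swap of one heavy atom at this position of the core can also move the number well beyond the scatter. Nothing available explains this step. As far as these compounds go, whether chloro does the same with 4-fluorophenyl or 4-methylphenyl on the sulfonyl sulfur remains open, as does how methoxy or an amine would read at this carbon.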